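This account rests on a few compounds, and the source may have more. Where it says the series, first, only, none or still open, it means among the compounds named here.

Working notes on the series.

Compound 1 `CC(C)(CNC(=O)c1ccccc1)CC1=C(O)C(=O)c2ccccc2C1=O` is the reference point. In a functional assay on MCF7 cells (Homo sapiens) for cytotoxicity, read by resazurin assay, with a stated time of 3 days (on this read-out lower numbers stand for stronger inhibition and higher numbers for weaker inhibition), compound 1 gives 37100 nM. Compound 2 `COC1=C(CC(C)(C)CNC(=O)c2ccccc2)C(=O)c2ccccc2C1=O` carries one change relative to compound 1, (methyl in place of hydrogen on an oxygen on an unsaturated carbon), and in this assay compound 2 gives 61800 nM; the step is a 1.7-fold higher number from compound 1 to compound 2 (0.22 log units; within the scatter). Compound 3 `COc1cc(C(=O)NCC(C)(C)CC2=C(O)C(=O)c3ccccc3C2=O)c(O)c2ccccc12` differs from compound 1 in more than one place; the difference between the two cores is not broken down here. In this assay compound 3 gives 35600 nM, which sits within the scatter of the value of compound 1 and also within the scatter of the value of compound 2, so the three measured compounds cannot be ordered against each other.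

Compound 4 `COc1cc(C(=O)NCC(C)(C)CC2=C(O)C(=O)c3ccccc3C2=O)c(OC)c2ccccc12` is not yet measured. It differs from compound 3 by methyl in place of hydrogen on an oxygen on an aromatic ring. For the measured compounds named here, this is the same kind of change as the one from compound 1 to compound 2, but the surroundings differ: in compound 2 the oxygen sits on an unsaturated carbon whose other neighbours are a double-bonded ring carbon, while in compound 4 the oxygen sits on an aromatic ring whose other neighbours are aromatic carbon.

Going by the values given here, the only precedent for this kind of change is the step from compound 1 to compound 2, which stayed within the scatter. Because a 1.7-fold higher number from compound 1 to compound 2 (0.22 log units; within the scatter) was small, compound 4 is expected to show a step of a 1.3-fold higher number from compound 3 to compound 4 (0.12 log units; within the scatter) in this assay. Among the compounds with values here, compound 4 is therefore estimated at 47000 nM, with a range from 22000 nM to 100000 nM, resting on the single precedent and on the different surroundings of the changed oxygen.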

Compound 4, half-maximal inhibitory concentration: "not active" (no number reported)
The entry for compound 4 holds no number; there is nothing to compare the estimate with.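

In this assay, for the compounds shown here, compound 4 is entered as "not active" with no number reported, so no step from compound 3 to compound 4 can be read. Nothing available bears on this result. The compounds shown leave open whether, and by how much, going from hydroxy to methoxy on the aromatic ring shifts the read-out of compound 3.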